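This account rests on a few compounds, and the source may have more. Where it says the series, first, only, none or still open, it means among the compounds named here.

Measured so far in a functional assay on NCI/ADR-RES cells (Homo sapiens) for inhibition, with a stated time of 48 h; a higher number here means a weaker inhibitor of growth, a lower number a stronger inhibitor of growth:

- compound 1 `COc1c(C(=O)/C=C/c2ccc(Cl)cc2)c(O)c(Br)c2occc12`: 3070 nM
- compound 2 `C=CCc1c(O)c(C(=O)/C=C/c2ccccc2)c(OC)c2ccoc12`: 1880 nM

The values of these two compounds lie within the usual scatter of each other, so compound 2 cannot be ranked apart from compound 1 on the numbers available. Within the data shown here, they are the only values at hand, and no two measured compounds differ in just one place.

Compound 3 `C=CCc1c(O)c(C(=O)/C=C/c2ccc(Cl)cc2)c(OC)c2ccoc12` keeps the structure of compound 2 except for one change: chloro in place of hydrogen on an aromatic carbon. Chloro takes the place of hydrogen on an aromatic carbon, para to a large group, so that phenyl becomes 4-chlorophenyl.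

Among the measured compounds shown here, with no measured step to guide it, the expectation rests on how close together the two known values are, compound 1 at 3070 nM and compound 2 at 1880 nM. In this assay only a modest shift is expected, towards stronger growth inhibition and not beyond the scatter. The estimated change is a 1.3-fold lower number from compound 2 to compound 3 (0.10 log units; within the scatter). The expected value for compound 3 is 1500 nM, within an estimated range of 600 nM to 3800 nM.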

Compound 3, concentration for 50% growth inhibition: 2230 nM
Estimate against measurement, compound 3: 1.5-fold (0.17 log units) below; the range from low to high includes it.
By their numbers in this assay, from the lowest: compounds 2, 3 and 1 (each within the scatter of the next).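

In this assay, chloro in place of hydrogen on an aromatic carbon, para to a large group, turning phenyl into 4-chlorophenyl, gives a 1.2-fold higher number from compound 2 to compound 3 (0.07 log units; within the scatter) and so leaves the two compounds indistinguishable. Among these compounds, this is the first measured step at this position, and on this allyl-bearing core the 4-chlorophenyl and phenyl forms cannot be told apart in this read-out. The second step, allyl in place of bromo on an aromatic carbon with the 4-chlorophenyl kept, gives a 1.4-fold lower number from compound 1 to compound 3 (0.14 log units; within the scatter) and separates its two compounds no better, so neither change moves the number beyond the scatter, and nothing at hand bears on why these values lie so close.

The compounds shown leave open whether an amine or a carboxylic acid in the place of chloro, or a longer chain such as hexyl in the place of allyl, would give a step beyond the scatter. As far as these compounds go, how the step from hydrogen to chloro reads with bromo in the place of allyl also stays open.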